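The source may report more compounds than this note shows. Statements on the series, on what has been measured and on what is new or still open speak of the compounds shown alone.

Compound 1, with the structure `C/C(=C\CC/C(C)=C/CC[C@@H]1[C@@]2(C)CCC(=O)C(C)(C)[C@H]2CC[C@@]1(C)O)CC/C=C(\C)C(=O)OCc1cn(-c2cccc(F)c2)nn1`, compound 2, with the structure `C/C(=C\CC/C(C)=C/CC[C@@H]1[C@@]2(C)CCC(=O)C(C)(C)[C@H]2CC[C@@]1(C)O)CC/C=C(\C)C(=O)OCc1cn(-c2ccccc2Br)nn1`, and compound 3, with the structure `C/C(=C\CC/C(C)=C/CC[C@@H]1[C@@]2(C)CCC(=O)C(C)(C)[C@H]2CC[C@@]1(C)O)CC/C=C(\C)C(=O)OCc1cn(-c2ccc(Cl)cc2)nn1`, share one core and differ only in the aryl group on the aromatic nitrogen. In a functional assay on DU-145 cells (Homo sapiens) for antiproliferative activity, read by MTT assay, with a stated time of 48 h (on this read-out lower numbers stand for stronger inhibition and higher numbers for weaker inhibition), compound 1 gives > 150000 nM, which is a limit of the assay and not a number. In this assay compound 2 gives > 150000 nM, again a limit rather than a number. In this assay compound 3 likewise gives > 150000 nM, a limit and not a number. The steps a step that the two limits leave unreadable from compound 1 to compound 2, a step that the two limits leave unreadable from compound 1 to compound 3 and a step that the two limits leave unreadable from compound 2 to compound 3 cannot be sized because every value shown sits at the limit of > 150000 nM in this assay, at which 3 of the 3 values shown sit. Compound 3 therefore stands only at that limit, with nothing in the shown numbers to separate it from the others.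

Compound 4, with the structure `COc1ccc(-n2cc(COC(=O)/C(C)=C/CC/C(C)=C/CC/C(C)=C/CC[C@@H]3[C@@]4(C)CCC(=O)C(C)(C)[C@H]4CC[C@@]3(C)O)nn2)cc1`, differs from compound 3 by methoxy in place of chloro on an aromatic carbon. For the measured compounds named here, no measured step bears on this change. Since all three measured analogues lie at the limit, compound 4 is expected to show 200000 nM, within 100000 nM to 500000 nM. The expected step that the limit leaves unreadable from compound 3 to compound 4 is thus estimated to end at the limit once more.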

Compound 4, half-maximal inhibitory concentration: 135000 nM
For compound 4 the middle estimate is 1.5-fold (0.17 log units) above the measured one; the range from low to high includes it.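

With 4-methoxyphenyl on the aromatic nitrogen, the series gains its first readable number, and methoxy in place of chloro, para to a large group, gives an at least 1.1-fold lower number from compound 3 to compound 4 (0.04 log units; that floor lies within the scatter). The comparisons with the other two aryl groups read the same way, with an at least 1.1-fold lower number from compound 2 to compound 4 (0.04 log units; that floor lies within the scatter) and an at least 1.1-fold lower number from compound 1 to compound 4 (0.04 log units; that floor lies within the scatter). Each of these steps is only a floor, so the change from any of these aryl groups to 4-methoxyphenyl is not shown to exceed the usual scatter, and the other three compounds still give no number: the limit of > 150000 nM in this assay, at which 3 of the 4 values shown sit.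

From the compounds shown here alone, how far compound 1, compound 2 and compound 3 actually lie from compound 4 stays open, so it is unclear whether the aryl group matters at all. Also open, going by these compounds, is what an amine or a carboxylic acid on this six-membered aromatic ring would give in this assay.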